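The source may report more compounds than this note shows. Statements on the series, on what has been measured and on what is new or still open speak of the compounds shown alone.

Working notes on the series. Among the measured compounds shown here, in a functional assay for inhibition, with Homo sapiens as the target (on this read-out lower numbers stand for stronger inhibition and higher numbers for weaker inhibition), compound 1 (`CCOC(=O)c1ccc(Nc2nccc(-c3cccnc3)n2)cc1`) gives 12400 nM and compound 2 (`FC(F)(F)c1cc(Nc2nccc(-c3ccncc3)n2)ccc1-n1ccnc1`) gives 400 nM as the only other number so far. Compound 1 therefore holds the higher of the two numbers, which means the weaker inhibition, and the gap lies beyond the scatter. The two structures differ in more than one place, so the gap cannot be tied to any single group.

Next in line is compound 3 (`Oc1ccc(Nc2nccc(-c3cccnc3)n2)cc1`), which keeps the core of compound 1 and carries hydroxy in place of ethoxycarbonyl on an aromatic carbon, para to a large group. The counted change is hydroxy in place of ethoxycarbonyl on an aromatic carbon and nothing else differs.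

For the measured compounds named here, no measured step bears on this exchange, so the expectation is a loose one. No step beyond the scatter is expected, with a slight lean toward a lower number. The estimate amounts to an expected 1.6-fold lower number from compound 1 to compound 3 (0.19 log units; within the scatter) and carries wide uncertainty. Compound 3 is estimated at 8000 nM with an expected range of 2000 nM to 30000 nM in this assay for now.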

Compound 3, half-maximal inhibitory concentration: 5100 nM
The estimate for compound 3 lay 1.6-fold (0.20 log units) above the measured number, within the range that was stated.
By their numbers in this assay, from the lowest: compound 2; then compound 3; then compound 1.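

Among the compounds shown here, at the aromatic carbon para to a large group, in this assay, hydroxy in place of ethoxycarbonyl gives a 2.4-fold lower number from compound 1 to compound 3 (0.39 log units; beyond the scatter), a modest step and the only one so far that can be tied to a single group. The exchange therefore shows that this position does not require the ethoxycarbonyl group for the activity seen with compound 1: the five heavy atoms of that group, with no hydrogen-bond donor, give way to the single oxygen of hydroxy, which brings one, and the number does not rise. No measurement in hand bears on what lies behind this step.

The compounds shown leave open whether the lower number goes with the hydroxy group itself or simply with the loss of ethoxycarbonyl, a question on which a methoxy group, an amine or a carboxylic acid on the same carbon would bear. On these data alone, compound 2 differs from compound 3 in more than one place, so how far its number depends on the group at this position also stays open.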